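Swapping a bromobenzyl ester for a cyclohexylmethyl ester

The source may hold more compounds than are shown below. What is called first, only, known or untested is meant among the compounds shown, and "the series" means these compounds.

Measured so far:
- compound 1 `COc1cc(O)c(C(=O)OCC2CCCCC2)c(/C=C/CN2C(=O)C=CC2=O)c1`: 1970 nM
- compound 2 `C=CS(=O)(=O)NC/C=C/c1cc(OC)cc(O)c1C(=O)OCc1ccc(Br)cc1`: 6060 nM
- compound 3 `CCN(CC)C/C=C/C(=O)NC/C=C/c1cc(OC)cc(O)c1C(=O)OC(C)C`: > 10000 nM

Of the compounds shown here, three have been tested in a functional assay on MV4-11 cells (Homo sapiens) for antiproliferative activity, read by luminescence, with a stated time of 72 h; on this read-out higher numbers stand for weaker inhibition and lower numbers for stronger inhibition. Compound 1 gives 1970 nM. Compound 2 gives 6060 nM, the highest of the two plain numbers, and a gap beyond the usual scatter from compound 1. Compound 3 reaches only a limit, > 10000 nM, and so gives no number; (the limit of > 10000 nM in this assay, at which 1 of the 3 values shown sits).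

The step studied here leads from compound 2 to compound 4 `C=CS(=O)(=O)NC/C=C/c1cc(OC)cc(O)c1C(=O)OCC1CCCCC1`, which is not yet measured. The change is cyclohexyl in place of 4-bromophenyl on a saturated chain carbon bound to an oxygen next to a carbonyl group. Cut one bond further out, it reads (4-bromobenzyl)oxy to cyclohexylmethoxy.

For the measured compounds named here, no measured pair differs only in this way, so the size of the step cannot be read from the data. Still, compound 1 also carries cyclohexylmethoxy, and compound 1 gives 1970 nM, so some gain is expected. For compound 4 the estimate is 3000 nM, within 1000 nM to 9000 nM. That would mean an expected step of a 2.0-fold lower number from compound 2 to compound 4 (0.31 log units; beyond the scatter).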

Compound 4, half-maximal inhibitory concentration: 5860 nM
Compound 4: the middle estimate sits 2.0-fold (0.29 log units) below what was measured; low and high end bracket the measured number.
By their numbers in this assay, from the lowest: compound 1; then compounds 4 and 2 (each within the scatter of the next). At a limit, above all of these: compound 3.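

In this assay, cyclohexyl in place of 4-bromophenyl gives a 1.0-fold lower number from compound 2 to compound 4 (0.01 log units; within the scatter), so on this read-out an aromatic ring and a non-aromatic ring of carbon cannot be told apart at this place in the ester. With the cyclohexylmethyl ester held constant, the open-chain group of compound 4 in place of the ring-bearing group of compound 1 gives a 3.0-fold higher number from compound 1 to compound 4 (0.47 log units; beyond the scatter), so in this pair a change at the other end of the molecule moves the number beyond the scatter. Nothing measured here accounts for either result.

Going by these compounds, it remains open whether this ester position would respond to a group carrying an amine or a carboxylic acid, or to a longer chain bearing the ring. On these data alone, it is also open whether 4-bromobenzyl and cyclohexylmethyl would still match alongside the ring-bearing group of compound 1.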